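Thiophenyl-substituted nucleoside analogues: extending to a dichlorophenyl

This account rests on a few compounds, and the source may have more. Where it says the series, first, only, none or still open, it means among the compounds named here.

Measured so far in an assay on isolated protein for binding affinity to Equilibrative nucleoside transporter 1 (Homo sapiens); on this read-out lower numbers stand for stronger inhibition and higher numbers for weaker inhibition:
- compound 1, `OC[C@H]1O[C@@H](n2cnc3c(CSc4c(F)cccc4Cl)ncnc32)[C@H](O)[C@@H]1O`: 1510 nM
- compound 2, `OC[C@H]1O[C@@H](n2cnc3c(CSc4ccccc4Cl)ncnc32)[C@H](O)[C@@H]1O`: 1780 nM
- compound 3, `OC[C@H]1O[C@@H](n2cnc3c(CSc4ccccc4I)ncnc32)[C@H](O)[C@@H]1O`: 282 nM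

Compound 3 stands lowest of the three numbers in this assay; the steps of a 5.4-fold lower number from compound 1 to compound 3 (0.73 log units; beyond the scatter) and a 6.3-fold lower number from compound 2 to compound 3 (0.80 log units; beyond the scatter) are both beyond the scatter, whereas a 1.2-fold higher number from compound 1 to compound 2 (0.07 log units; within the scatter) is within it. Compound 4, `OC[C@H]1O[C@@H](n2cnc3c(CSc4ccc(Cl)c(Cl)c4)ncnc32)[C@H](O)[C@@H]1O`, differs from compound 3 by 3,4-dichlorophenyl in place of 2-iodophenyl on a sulfur. Going by the values given here, no measured step bears directly on a 3,4-dichlorophenyl; the only relevant comparison is compound 2 against compound 3, where the chloro-bearing ring gave the higher number. Compound 4 is therefore expected to give a higher number than compound 3 in this assay, an estimated step of a 3.2-fold higher number from compound 3 to compound 4 (0.50 log units; beyond the scatter). Compound 4 is estimated at 900 nM, with a range of 250 nM to 3200 nM.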

Compound 4, half-maximal inhibitory concentration: 224 nM
Beside the measured number, compound 4's estimate is 4.0-fold (0.60 log units) above it, and the stated range ends above it.
By their numbers in this assay, from the lowest: compounds 4 and 3 (each within the scatter of the next); then compounds 1 and 2 (each within the scatter of the next).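

On the sulfur, 3,4-dichlorophenyl in place of 2-iodophenyl stays within the scatter (a 1.3-fold lower number from compound 3 to compound 4 (0.10 log units; within the scatter)), so iodine is not needed for numbers at this level: a ring carrying only chlorine reaches it too. Chlorine alone therefore does not set the higher numbers, as the steps of a 7.9-fold lower number from compound 2 to compound 4 (0.90 log units; beyond the scatter) and a 6.7-fold lower number from compound 1 to compound 4 (0.83 log units; beyond the scatter) separate this ring from the 2-chlorophenyl and 2-chloro-6-fluorophenyl rings. No data on hand explain these steps. Open, on these data alone, is whether both chlorines of the 3,4-dichlorophenyl are needed, and how an amine or a methoxy group on that ring would read.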